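Benzyloxy Tail in Place of Ethoxy on the Shared Core

The compounds below may be only part of what the source reports. "The series", "measured", "known", "first", "only" and "open" are said of these compounds alone.

Compound 2 `CCOCCNC(=O)n1c(=O)oc2cc(C3CCN(C)CC3)ccc21` holds the second highest of three numbers in an assay on HEK293 cells for inhibition of acid ceramidase (Homo sapiens), read by fluorescence, with stated times of 10 min and 3 h; a higher number here means a weaker inhibitor, a lower number a stronger inhibitor: compound 2 gives 1050 nM in this assay. Its nearest neighbour is compound 3 `CCOCCNC(=O)n1c(=O)oc2cc(-c3ccc(F)cc3)ccc21`, which gives 2300 nM, and its furthest is compound 1 `CC(=O)N1CCC(c2ccc3c(c2)oc(=O)n3C(=O)NCCCCc2ccccc2)CC1`, which gives 64 nM. Going by the values given here, the only step measured in one place runs a 2.2-fold higher number from compound 2 to compound 3 (0.34 log units; beyond the scatter); it concerns the group on the aromatic carbon, not the chain on the amide nitrogen, so it does not bear directly on the change considered here.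

Compound 4 `CN1CCC(c2ccc3c(c2)oc(=O)n3C(=O)NCCOCc2ccccc2)CC1` differs from compound 2 in one place: phenyl in place of methyl on a saturated chain carbon bound to an oxygen on a saturated carbon. Among the compounds with values here, no measured pair isolates this change. Within the data shown here, compound 1 and compound 2 differ in two places, the group on the saturated ring nitrogen as well as the chain, so their values show only that the one compound carrying a phenyl at the end of its chain, compound 1, stands far lower in this assay than compound 2 does, without saying how much of that gap belongs to the chain.

On that limited basis compound 4 is expected to give a lower number than compound 2, with the expected step being a 3.5-fold lower number from compound 2 to compound 4 (0.54 log units; beyond the scatter). The estimate for compound 4 in this assay is 300 nM, within a range from 90 nM to 1000 nM.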

Compound 4, half-maximal inhibitory concentration: 215 nM
Beside the measured number, compound 4's estimate is 1.4-fold (0.14 log units) above it; the range from low to high includes it.
By their numbers in this assay, from the lowest: compound 1; then compound 4; then compound 2; then compound 3.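

With a 4.9-fold lower number from compound 2 to compound 4 (0.69 log units; beyond the scatter) in this assay, the chain on the amide nitrogen now has a measured pair that isolates a change, with the 1-methylpiperidin-4-yl group and the shared core held constant. Going by these compounds alone, the earlier single step concerned only the group on the aromatic carbon, so this is the first direct reading of ethoxy becoming benzyloxy: a phenyl in place of a methyl, on a saturated chain carbon bound to an oxygen on a saturated carbon, goes with a lower number by a margin beyond the usual scatter. The finding rests on this one pair, and nothing at hand accounts for the size or direction of the step.

The compounds shown leave open whether the same change gives a similar step when 4-fluorophenyl stands on the aromatic carbon, or when the methyl on the saturated ring nitrogen is replaced by acetyl. They also leave open whether the phenyl itself matters or whether a cyclohexyl ring, a pyridine ring or a longer chain at the same place would give a similar number.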